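The source may report more compounds than this note shows. Statements on the series, on what has been measured and on what is new or still open speak of the compounds shown alone.

Compound 1 `COc1ccc(S(=O)(=O)Nc2ccc(-c3nc4ccccc4o3)cc2)cc1`. In an assay on cells for inhibition of HSP60/HSP10 (Homo sapiens), with a stated time of 60 min (on this read-out lower numbers stand for stronger inhibition and higher numbers for weaker inhibition), compound 1 reaches only a limit, > 100000 nM.
Compound 2 `O=S(=O)(Nc1ccc(-c2nc3ccccc3o2)cc1)c1ccc(Cl)s1`. Compound 2 gives 31000 nM.
Compound 3 `O=S(=O)(Nc1ccc(-c2nc3ccccc3o2)cc1)c1cccc(C(F)(F)F)c1`. Compound 3 gives 57000 nM.

Compound 3 and compound 2 lie within the scatter of each other, while compound 1 sits at a limit (the limit of > 100000 nM in this assay, at which 1 of the 3 values shown sits). Compound 4 `O=S(=O)(Nc1ccc(-c2nc3ccccc3o2)cc1)c1cccc(F)c1` differs from compound 3 by fluoro in place of trifluoromethyl on an aromatic carbon. For the measured compounds named here, the only measured step, an at least 3.2-fold lower number from compound 1 to compound 2 (0.50 log units; beyond the scatter), also alters the group on the sulfonyl sulfur, but exchanges the whole ring rather than one substituent, so it offers limited guidance. For compound 4 the step of a 1.1-fold higher number from compound 3 to compound 4 (0.02 log units; within the scatter) is expected to stay within the scatter. Compound 4 is estimated at 60000 nM, in the range 25000 nM to 150000 nM.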

Compound 4, half-maximal inhibitory concentration: 71000 nM
Estimate against measurement, compound 4: 1.2-fold (0.07 log units) below; the range from low to high includes it.
By their numbers in this assay, from the lowest: compounds 2, 3 and 4 (each within the scatter of the next, the first and the last beyond it). At a limit, above all of these: compound 1.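

In this assay fluoro in place of trifluoromethyl on this aromatic carbon gives a 1.2-fold higher number from compound 3 to compound 4 (0.10 log units; within the scatter) and so does not tell the two groups apart. The exchange of the whole group on the sulfonyl sulfur does separate two compounds, with 3-fluorophenyl in place of 5-chlorothiophen-2-yl giving a 2.3-fold higher number from compound 2 to compound 4 (0.36 log units; beyond the scatter) in a modest step. With 3-fluorophenyl in place of 4-methoxyphenyl the comparison prints an at least 1.4-fold lower number from compound 1 to compound 4 (0.14 log units; that floor lies within the scatter) as its only figure. This step cannot be read, because compound 1 stands at a limit: the limit of > 100000 nM in this assay, at which 1 of the 4 values shown sits.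

On these data alone, whether an amine or a carboxylic acid on this carbon would move the number beyond the scatter stays open. So does whether any group here can bring the number well below these values.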